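Adding a chloro to the benzimidazole ring of compound 2

This account rests on a few compounds, and the source may have more. Where it says the series, first, only, none or still open, it means among the compounds named here.

Compound 1 `CC(=O)N1CCC(C[C@@H](c2nc3ccc(Cl)cc3n2C)N2C(=O)CN(c3ccc(Oc4ccccc4)cc3)C2=O)CC1`: 3500 nM
Compound 2 `CC(C)C(=O)N1CCC(C[C@@H](c2nc3ccccc3n2C)N2C(=O)CN(c3ccc(Oc4ccccc4)cc3)C2=O)CC1`: 38 nM

In an assay on isolated protein for antagonist activity at Bile acid receptor (Homo sapiens), read by TR-FRET and LanthaScreen (on this read-out higher numbers stand for weaker inhibition and lower numbers for stronger inhibition), compound 2 gives the lower of the two values, and its gap to compound 1 lies well beyond the usual scatter. Compound 1 and compound 2 differ in two places at once, so no single change can be read from that pair. Compound 3 `CC(C)C(=O)N1CCC(C[C@@H](c2nc3ccc(Cl)cc3n2C)N2C(=O)CN(c3ccc(Oc4ccccc4)cc3)C2=O)CC1` carries the change (chloro in place of hydrogen on an aromatic carbon), that is chloro in place of hydrogen on an aromatic carbon. For the measured compounds named here, with no measured pair isolating this change, a modest weakening is expected, a 2.6-fold higher number from compound 2 to compound 3 (0.42 log units; beyond the scatter). Compound 3 is estimated at 100 nM, with a likely range from 25 nM to 600 nM.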

Compound 3, half-maximal inhibitory concentration: 130 nM
The estimate for compound 3 lay 1.3-fold (0.11 log units) below the measured number; the measured number falls inside the stated range.
By their numbers in this assay, from the lowest: compound 2; then compound 3; then compound 1.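

In this assay, the chloro on the aromatic carbon costs only a modest amount, with a 3.4-fold higher number from compound 2 to compound 3 (0.53 log units; beyond the scatter) and the isopropyl in place of methyl on the carbonyl carbon gives a far larger change, with a 27-fold lower number from compound 1 to compound 3 (1.43 log units; beyond the scatter) as its step. Most of the gap between compound 1 and compound 2 therefore goes with the group on the carbonyl carbon, not with the chloro. No measurement here explains either step. On these data alone, what remains open is whether fluoro or methoxy on the same aromatic carbon would match chloro. Also open, as far as these compounds go, is whether cyclopropyl or a longer chain on the carbonyl carbon would give a lower number than isopropyl.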